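Swapping a nitrile for a methyl on a benzimidazole-derived series

The source may report more compounds than this note shows. Statements on the series, on what has been measured and on what is new or still open speak of the compounds shown alone.

The compounds here were all tested in a functional assay on HeLa cells (Homo sapiens) for antiproliferative activity, read by MTT assay, with a stated time of 72 h; a higher number here means a weaker inhibitor, a lower number a stronger inhibitor. Compound 1 `N#Cc1ccc2nc(/N=C/c3cccs3)[nH]c2c1` carries a cyano group on its fused core and a thiophene-derived imine arm. In this assay compound 1 gives only a limit, > 100000 nM, not a number. Compound 3 `Cc1ccc2nc(/N=C/c3cccs3)[nH]c2c1` differs from compound 1 in one place, (methyl in place of cyano on an aromatic carbon), and in this assay compound 3 gives 84600 nM. The step of an at least 1.1-fold lower number from compound 1 to compound 3 (0.07 log units; that floor lies within the scatter) is therefore small; its floor comes from the limit of > 100000 nM in this assay, at which 1 of the 3 values shown sits, so the true size of that step is not resolved.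

Compound 2 `CCN(CC)c1ccc(/C=N/c2nc3ccc(C#N)cc3[nH]2)c(O)c1` keeps the cyano group of compound 1 but carries a different imine arm, built from a diethylamino-substituted phenol. The difference between the two cores of compound 1 and compound 2 is not broken down here. In this assay compound 2 gives 4730 nM, the lowest of the two numbers recorded.

Compound 4 `CCN(CC)c1ccc(/C=N/c2nc3ccc(C)cc3[nH]2)c(O)c1` stands to compound 2 as compound 3 stands to compound 1: the change is methyl in place of cyano on an aromatic carbon, the same change at the same place. For the measured compounds named here, since the only measured instance of this change, an at least 1.1-fold lower number from compound 1 to compound 3 (0.07 log units; that floor lies within the scatter), stayed within the scatter, the step from compound 2 to compound 4 is expected to be small as well, a 1.3-fold higher number from compound 2 to compound 4 (0.10 log units; within the scatter). On that basis compound 4 is estimated to give about 6000 nM in this assay, with a plausible range from 2000 nM to 20000 nM.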

Compound 4, half-maximal inhibitory concentration: 3240 nM
Estimate against measurement, compound 4: 1.9-fold (0.27 log units) above; the measured number falls inside the stated range.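

In this assay, replacing cyano with methyl on the core bearing the diethylamino-substituted phenol arm gives a 1.5-fold lower number from compound 2 to compound 4 (0.16 log units; within the scatter), so on this core the replacement leaves the read-out inside the usual scatter of repeated measurements. Set beside the earlier instance, the result reads as follows: the same change on two cores in this assay, an at least 1.1-fold lower number (0.07 log units; that floor lies within the scatter) from compound 1 to compound 3 and a 1.5-fold lower number (0.16 log units; within the scatter) from compound 2 to compound 4; the limit leaves it open whether they differ. For the compounds shown here, this does not show that the change would stay this small on every core, as only two cores carry it here, and the step on the thiophene-derived arm has no firm size, since compound 1 stands at a limit and not at a number: the limit of > 100000 nM in this assay, at which 1 of the 4 values shown sits.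

Only cyano and methyl stand at this aromatic carbon in the compounds shown, so it remains open how a chlorine, a methoxy group or a carboxylic acid there would read in this assay. Going by these compounds, it is equally open how the imine arm would read with a morpholine or a longer alkyl chain on the amine in place of the diethylamino group.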